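Thiourea in Place of Cyanoguanidine on a Pyridazinone Chain

The compounds below may be only part of what the source reports. "The series", "measured", "known", "first", "only" and "open" are said of these compounds alone.

Measured compounds and their results in a functional assay on the whole organism with Rattus norvegicus as the target; a higher number here means that more compound is needed for the effect, a lower number that less compound is needed:
- compound 1, `C/N=C(\NC#N)NCCCCn1nc(-c2ccccc2)ccc1=O`, gives 38.5 mg/kg
- compound 2, `C/N=C(/NC#N)NCCCn1nc(-c2ccccc2)ccc1=O`, gives 78.1 mg/kg
- compound 3, `C/N=C(\S)NCCCCCn1nc(-c2ccccc2)ccc1=O`, gives 42.1 mg/kg

Compound 1 stands lowest of the three numbers in this assay. Its nearest neighbour is compound 3, at a 1.1-fold higher number from compound 1 to compound 3 (0.04 log units; within the scatter), so the two are not separated by the measurement. Compound 2 lies furthest, at a 2.0-fold higher number from compound 1 to compound 2 (0.31 log units; beyond the scatter), a modest step.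

Compound 4, `O=c1ccc(-c2ccccc2)nn1CCCCNC(=S)Nc1ccccc1`, is reached from compound 1 by a single change: a group of 9 heavy atoms (7 carbon, 1 nitrogen, 1 sulfur; one six-membered aromatic ring of carbon only) in place of a group of 6 heavy atoms (3 carbon, 3 nitrogen; no ring), on an amine nitrogen. The step from compound 1 to compound 3 bears on this most directly, because it also replaces the cyanoguanidine part with a thiourea-type group and gave a 1.1-fold higher number from compound 1 to compound 3 (0.04 log units; within the scatter), within the scatter. The step from compound 1 to compound 2 concerns the chain length rather than the end group and is less informative here. Going by the values given here, no measured pair shows what a six-membered aromatic ring of carbon only on the thiourea nitrogen does in place of a methyl group, so that part of the change is uncovered.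

On this basis the number for compound 4 is expected to sit close to that of compound 1, an estimated 1.2-fold higher number from compound 1 to compound 4 (0.07 log units; within the scatter), with the uncertainty widened by the untested aromatic ring. Compound 4 is therefore estimated at 45 mg/kg, in a range from 20 mg/kg to 110 mg/kg.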

Compound 4, dose for half-maximal effect: > 100 mg/kg
Compound 4 ended at the assay's limit; the forecaster's own chance of this, stated with the estimate: 10%; middle value at least 2.2-fold (0.34 log units) from the limit.
By their numbers in this assay, from the lowest: compounds 1, 3 and 2 (each within the scatter of the next, the first and the last beyond it). At a limit, above all of these: compound 4.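

In this assay compound 4 gives > 100 mg/kg, which is a limit of the assay and not a number: the limit of > 100 mg/kg in this assay, at which 1 of the 4 values shown sits.

Placing the group with a six-membered aromatic ring of carbon only on the amine nitrogen, in place of the cyanoguanidine end of compound 1, gave an at least 2.5-fold higher number from compound 1 to compound 4 (0.41 log units; beyond the scatter), so this position does not accept every change of end group without a loss in this test. The earlier step of a 1.1-fold higher number from compound 1 to compound 3 (0.04 log units; within the scatter) had shown a sulfur-bearing end group with no separation from compound 1, whereas this new change, which also brings in the ring, shows a clear separation whose full size stays unknown at the limit.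

The compounds shown do not separate the part played by the thiourea from the part played by the aromatic ring, and a thiourea with a simple methyl group on the chain of compound 4 would be the direct test of that. Nor do they show whether a benzyl group, a cyclohexyl ring or a pyridine ring on that nitrogen would bring the dose back towards that of compound 1.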